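A few compounds are considered here, and "the series" means these few. Any claim that something is new, unique, unknown or untested is made for them only; others in the source may bear on it.

In a functional assay on K562/A02 cells (Homo sapiens) for antiproliferative activity, read by MTT assay (a higher number here means a weaker inhibitor, a lower number a stronger inhibitor), compound 1 `O=C(CCCCCNC(=S)NN=C(c1ccccn1)c1ccccn1)NO` gives 2180 nM and compound 2 `O=C(CCCCCNC(=S)NN=C(c1ccccc1)c1ccccc1)NO` gives 3640 nM. Compound 3 `C/C(=N\NC(=S)NCCCCCC(=O)NO)c1ccc(Br)cc1` gives 440 nM, the lowest of the three numbers and beyond the scatter from both others. Compound 4 `COc1cccc(/C(C)=N/NC(=S)NCCCCCC(=O)NO)c1` has not yet been measured. It carries 3-methoxyphenyl in place of 4-bromophenyl on a carbon with a double bond to nitrogen. For the measured compounds named here, no measured pair shows a change of this kind, so the size of the step in this assay cannot be read from precedent. A moderate rise is expected because compound 3 at 440 nM stands lowest so far. The estimated change is a 2.0-fold higher number from compound 3 to compound 4 (0.31 log units; beyond the scatter). For compound 4 the estimated value is 900 nM, with an expected range of 300 nM to 2700 nM.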

Compound 4, half-maximal inhibitory concentration: 1890 nM
For compound 4 the middle estimate is 2.1-fold (0.32 log units) below the measured one; the measured number falls inside the stated range.
By their numbers in this assay, from the lowest: compound 3; then compounds 4, 1 and 2 (each within the scatter of the next).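

In this assay, for the compounds shown here, 3-methoxyphenyl in place of 4-bromophenyl on a carbon with a double bond to nitrogen gives a 4.3-fold higher number from compound 3 to compound 4 (0.63 log units; beyond the scatter), the first step that can be read at this position. It shows that the number here responds to the aromatic group, and that the low number of compound 3 does not survive this change. No evidence at hand accounts for the step. The compounds shown leave open whether the step follows the group itself or its place on the ring. A 4-methoxyphenyl or a 3-bromophenyl group would separate the two.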